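A few compounds are considered here, and "the series" means these few. Any claim that something is new, unique, unknown or untested is made for them only; others in the source may bear on it.

Compound 2 `CCc1ccccc1N(CC(=O)NCc1ccc(Cl)cc1)S(=O)(=O)c1ccc(C)cc1` is the reference point of this account. Among the compounds with values here, in a functional assay on CHO-K1 cells for antagonist activity at prostaglandin E2 receptor EP1 subtype (Homo sapiens), read by FLIPR and calcium flux (a lower number here means a stronger inhibitor, a higher number a weaker inhibitor), compound 2 gives 11.5 nM, the lowest of the three numbers known here. Compound 3 `CCc1ccccc1N(CC(=O)NCc1ccccc1F)S(=O)(=O)c1ccc(C)cc1` gives 135 nM in this assay, and compound 1 `CCc1ccccc1N(CC(=O)NCc1ccc(OC)c(OC)c1)S(=O)(=O)c1ccc(C)cc1` gives 282 nM; the gaps are a 12-fold higher number from compound 2 to compound 3 (1.07 log units; beyond the scatter) and a 25-fold lower number from compound 1 to compound 2 (1.39 log units; beyond the scatter), with a 2.1-fold lower number from compound 1 to compound 3 (0.32 log units; beyond the scatter) between the other two.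

Compound 4 `Cc1ccc(S(=O)(=O)N(CC(=O)NCc2ccc(Cl)cc2)c2cccc(C)n2)cc1` differs from compound 2 by 6-methylpyridin-2-yl in place of 2-ethylphenyl on a sulfonamide nitrogen. All three measured steps concern the aryl group on the saturated chain carbon bound to the amide-type nitrogen, not the sulfonamide nitrogen, so none of them bears directly on this change; they show only that the series can move by large amounts when one aryl group is swapped. Within the data shown here, with no measured precedent at this position, a step of modest size in this assay is expected from compound 2 to compound 4, a 3.5-fold higher number from compound 2 to compound 4 (0.54 log units; beyond the scatter), in either direction, with a wide range. Compound 4 is therefore estimated at 40 nM, between 5 nM and 400 nM.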

Compound 4, inhibition constant: < 1450 nM
Compound 4 ended at the assay's limit (the forecaster's own chance of this, stated with the estimate: 5%); the middle value lies beyond the limit too.
By their numbers in this assay, from the lowest: compound 2; then compound 3; then compound 1.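

In this assay compound 4 gives < 1450 nM, which is a limit of the assay and not a number. The step from compound 2 to compound 4 cannot be read. The compounds shown leave open how far 6-methylpyridin-2-yl in place of 2-ethylphenyl on a sulfonamide nitrogen moves the number.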